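The source may report more compounds than this note shows. Statements on the series, on what has been measured and on what is new or still open speak of the compounds shown alone.

For the measured compounds named here, in a functional assay on HCT-116 cells (Homo sapiens) for inhibition, read by CCK-8 assay, with a stated time of 72 h, tested at 2 uM (a lower number here means less inhibition of growth, a higher number more inhibition of growth at the concentration tested), compound 1 `Nc1ccccc1NC(=O)c1ccc(CSc2cccc(F)c2)cc1` gives a low number (5.5%), whereas compound 2 `Cc1ccc(SCc2ccc(C(=O)Nc3ccccc3N)cc2)cc1` holds the higher of the two values so far (74.8%), a gap beyond the scatter. Going by the values given here, the only measured step (a number 69.3 percentage points higher from compound 1 to compound 2 (beyond the scatter)) is large and concerns the same aromatic group on sulfur, 4-methylphenyl in place of 3-fluorophenyl. Compound 3 `Nc1ccccc1NC(=O)c1ccc(CSc2ccc(Br)cc2)cc1` keeps the core of compound 2 and changes that group again (bromo in place of methyl on an aromatic carbon), with bromo in place of methyl on an aromatic carbon, para to a large group. Among the compounds with values here, the measured step shows that this group can move the number strongly, but no measured compound carries bromo, so the guidance is thin. A moderate fall is expected (a number 19.8 percentage points lower from compound 2 to compound 3 (beyond the scatter)), with wide uncertainty. Compound 3 is estimated at 55% with an expected range from 20% to 85% in this measurement.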

Compound 3, percent growth inhibition at one concentration: 9.96%
Compound 3: middle estimate off by 45 percentage points, on the high side; the whole stated range lies above it.
By their numbers in this assay, from the lowest: compounds 1 and 3 (each within the scatter of the next); then compound 2.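

In this assay, putting bromo in place of methyl on the same aromatic carbon gives a number 64.8 percentage points lower from compound 2 to compound 3 (beyond the scatter), so exchanging one heavy atom at this place is enough to lose most of the growth inhibition. The 4-bromophenyl and 3-fluorophenyl groups on sulfur are not separated, with a number 4.5 percentage points higher from compound 1 to compound 3 (within the scatter), so among these three compounds only the 4-methylphenyl group gives a high number. No measurement of any property of these groups is at hand to account for this difference.

As far as these compounds go, whether the high number is particular to methyl or also appears with ethyl, methoxy or chloro on that aromatic carbon remains open. From the compounds shown here alone, it is also open whether the 4-methylphenyl group keeps its number when an oxygen atom takes the place of the sulfur.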